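The source may report more compounds than this note shows. Statements on the series, on what has been measured and on what is new or still open speak of the compounds shown alone.

Compound 1, `O=C(/C=C/c1ccc(N2CCCCC2)cc1)c1cccs1`, in an ADME assay on Vero cells (Chlorocebus sabaeus) for cytotoxicity, with a stated time of 5 days (a higher number here means a weaker inhibitor, a lower number a stronger inhibitor), gives 65500 nM.
Compound 2, `O=C(/C=C/c1ccc(N2CCCCC2)cc1)c1ccsc1`, in this assay gives 34400 nM.
Compound 3, `c1csc(C2=NNC(c3ccc(N4CCCCC4)cc3)C2)c1`, in this assay gives 3200 nM.

Compound 3 has the lowest of the three numbers in this assay: compound 2 stands nearest to it and compound 1 furthest from it, both of them higher and both beyond the scatter. Compound 4, `c1cc(C2=NNC(c3ccc(N4CCCCC4)cc3)C2)cs1`, has the same atoms as compound 3 joined differently: thiophen-3-yl in place of thiophen-2-yl on a carbon with a double bond to nitrogen, with the new group sitting on a carbon with a double bond to nitrogen.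

Going by the values given here, one measured step bears on this change. From compound 1 to compound 2 the same swap of thiophen-2-yl for thiophen-3-yl was made on a carbonyl carbon, and it gave a 1.9-fold lower number from compound 1 to compound 2 (0.28 log units; within the scatter). Among the compounds with values here, that step lies within the scatter, so no firm direction can be read from it, and there is no second pair to show whether the swap behaves the same on the core of compound 3. On this basis compound 4 is expected to show only a small step, if any, a 1.3-fold lower number from compound 3 to compound 4 (0.11 log units; within the scatter), leaning toward a slightly lower number. The estimate for compound 4 in this assay is therefore 2500 nM, with a range from 1000 nM to 7000 nM.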

Compound 4, half-maximal inhibitory concentration: 29500 nM
For compound 4 the middle estimate is 12-fold (1.07 log units) below the measured one, and the stated range ends below it.
By their numbers in this assay, from the lowest: compound 3; then compounds 4, 2 and 1 (each within the scatter of the next, the first and the last beyond it).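

In this assay the attachment point of the thiophene turns out to matter on this core: thiophen-3-yl in place of thiophen-2-yl, on a carbon with a double bond to nitrogen, gives a 9.2-fold higher number from compound 3 to compound 4 (0.96 log units; beyond the scatter) and so is a real step, although the group that leaves and the group that enters have identical counts of heavy atoms, donors and acceptors. The only earlier case of this swap, on a carbonyl carbon, gave a 1.9-fold lower number from compound 1 to compound 2 (0.28 log units; within the scatter) and stayed within the scatter, so the two pairs show that a swap that is unresolved in one setting can be clearly resolved in another and that the earlier step did not predict this one. Nothing shown here accounts for the difference between the two settings.

On these data alone, with one pair on each core, it remains open whether the larger step belongs to this position generally or only to these two compounds. As far as these compounds go, it is also open how a methyl group or a carboxylic acid on the thiophene ring would change the number in this assay on the core of compound 3 or on the core of compound 4.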